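Trimming a Methyl from the Anilide of Compound 1

The source may report more compounds than this note shows. Statements on the series, on what has been measured and on what is new or still open speak of the compounds shown alone.

Compound 1 `Cc1ccc(NC(=O)CN2CCN(c3nnc(Cc4ccncc4)c4ccccc34)CC2)c(C)c1` gives 240 nM in a functional assay on MDA-MB-231 cells (Homo sapiens) for cytotoxicity, read by MTT assay, with a stated time of 72 h (on this read-out higher numbers stand for weaker inhibition and lower numbers for stronger inhibition), the lowest number among the three measured compounds. Compound 3 `O=C(CN1CCN(c2nnc(Cc3ccccc3)c3ccccc23)CC1)Nc1ccc(F)c(F)c1` gives 2750 nM, and compound 2 `COc1ccc(NC(=O)CN2CCN(c3nnc(Cc4ccccc4)c4ccccc34)CC2)cc1OC` gives 32200 nM. For the measured compounds named here, the one single-point step between measured compounds, a 12-fold lower number from compound 2 to compound 3 (1.07 log units; beyond the scatter), shows how strongly the aryl group on the amide-type nitrogen can move the read-out. Compound 4 `Cc1ccccc1NC(=O)CN1CCN(c2nnc(Cc3ccncc3)c3ccccc23)CC1` differs from compound 1 by hydrogen in place of methyl on an aromatic carbon. Going by the values given here, no measured step removes a methyl from that ring, so the only guide is a 12-fold lower number from compound 2 to compound 3 (1.07 log units; beyond the scatter), a large change from a different substitution on the same ring. For compound 4 a moderate step toward a higher number is expected, a 2.3-fold higher number from compound 1 to compound 4 (0.36 log units; beyond the scatter). Compound 4 is estimated at 550 nM, with a range from 150 nM to 2200 nM.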

Compound 4, half-maximal inhibitory concentration: 200 nM
The estimate for compound 4 lay 2.8-fold (0.44 log units) above the measured number, within the range that was stated.
By their numbers in this assay, from the lowest: compounds 4 and 1 (each within the scatter of the next); then compound 3; then compound 2.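

In this assay the change from 2,4-dimethylphenyl to 2-methylphenyl brings a 1.2-fold lower number from compound 1 to compound 4 (0.08 log units; within the scatter) and so shows that the methyl para to a large group can be replaced by hydrogen without a change beyond the scatter. Not every change on this ring therefore moves the read-out as much as a 12-fold lower number from compound 2 to compound 3 (1.07 log units; beyond the scatter) does. Nothing available here explains this result.

The compounds shown leave open whether a chlorine or a methoxy in this place would keep the number. They also leave open whether the remaining methyl could give way to hydrogen, leaving a plain phenyl.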